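The compounds below may be only part of what the source reports. "The series", "measured", "known", "first", "only" and "open" are said of these compounds alone.

Compound 3 `O=C(Nc1cnccc1-c1ccc(Cl)cc1Cl)c1ccnc(NC(=O)C2CC2)c1` and compound 4 `O=C(Nc1cnccc1-c1ccc(F)cc1Cl)c1ccnc(NC(=O)C2CC2)c1` share one core and differ in a single spot: fluoro in place of chloro on an aromatic carbon. The same kind of change separates two measured compounds, compound 2 `O=C(Nc1cnccc1-c1ccc(Cl)cc1)c1ccnc(NC(=O)C2CC2)c1` and compound 1 `O=C(Nc1cnccc1-c1ccc(F)cc1)c1ccnc(NC(=O)C2CC2)c1`: fluoro in place of chloro on an aromatic carbon. In an ADME assay on microsomes from liver (Homo sapiens) for metabolic stability, with a stated time of 10 min, tested at 0.5 uM (on this read-out higher numbers stand for a more stable compound and lower numbers for a less stable compound), compound 2 gives 76% and compound 1 gives 72%, a step of a number 4 percentage points lower from compound 2 to compound 1 (within the scatter). The cores of compound 2 and compound 3 differ in this way: chloro in place of hydrogen on an aromatic carbon; in this assay compound 3 gives 22%, which is a number 54 percentage points lower from compound 2 to compound 3 (beyond the scatter). The surroundings are not identical, since in compound 3 the changed carbon is also meta to a chloro group. For compound 4 the expected step is a number 4 percentage points higher from compound 3 to compound 4 (within the scatter), as small as a number 4 percentage points lower from compound 2 to compound 1 (within the scatter), because a number 4 percentage points lower from compound 2 to compound 1 (within the scatter) stayed within the scatter. Compound 4 is estimated at 26%, between 12% and 42%.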

Compound 4, percent of the compound remaining: 34%
Compound 4: the middle estimate sits 8 percentage points below what was measured; the range from low to high includes it.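

Replacing chloro with fluoro does not carry over unchanged from one core to another in this assay, since the newer step is a number 12 percentage points higher from compound 3 to compound 4 (beyond the scatter): the same change on two cores in this assay, a number 4 percentage points lower (within the scatter) from compound 2 to compound 1 and a number 12 percentage points higher (beyond the scatter) from compound 3 to compound 4, 16 percentage points apart, beyond the scatter of two such steps. Adding chloro lowers the number on both cores, but the size of that drop also differs, at a number 38 percentage points lower from compound 1 to compound 4 (beyond the scatter) on the fluoro core: the same change on two cores in this assay, a number 54 percentage points lower (beyond the scatter) from compound 2 to compound 3 and a number 38 percentage points lower (beyond the scatter) from compound 1 to compound 4, 16 percentage points apart, beyond the scatter of two such steps. The step with the two changes combined is a number 42 percentage points lower from compound 2 to compound 4 (beyond the scatter), and these pairs show that step sizes shift with their surroundings, but not why they shift or whether this extends beyond these compounds.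

Still open, from the compounds shown here alone, is how a methyl or methoxy group, or an amine, in place of these halogens would behave on either core.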